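The compounds below may be only part of what the source reports. "The series", "measured", "known", "first", "only" and "open" are said of these compounds alone.

Measured compounds in a physicochemical assay for lipophilicity, read by HPLC, at pH 7.5; on this read-out lower numbers stand for lower lipophilicity and higher numbers for higher lipophilicity:
- compound 1 `CC[C@@H](Nc1c(C#N)c(-c2ccc(-c3cccc(C)c3F)cc2)nc2cnccc12)C(N)=O`: compound 1 gives 3
- compound 2 `CCOc1ccccc1-c1ccc(-c2nc3cnccc3c(N[C@H](CC)C(=O)NS(=O)(=O)C3CC3)c2C#N)cc1`: compound 2 gives 2.3
- compound 3 `CCOc1ccccc1-c1ccc(-c2nc3cnccc3c(N)c2C#N)cc1`: compound 3 gives 3

Compound 1 stands level with compound 3 at the digits shown, and the two of them are together the highest of the three numbers; the gap to compound 2 is the only one beyond the scatter, compound 2 reading lower than compound 1 in this assay.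

For the measured compounds named here, the one step measured so far in this assay runs a number 0.70 log units higher from compound 2 to compound 3 (beyond the scatter). It concerns a hydrogen in place of a larger group on an aromatic-ring nitrogen, a change of a different kind from the one now in question.

Compound 4 `CC[C@@H](Nc1c(C#N)c(-c2ccc(Br)cc2)nc2cnccc12)C(N)=O` is the next compound, not yet measured. bromo in place of 2-fluoro-3-methylphenyl on an aromatic carbon A group of eight heavy atoms leaves and a single bromine enters. Going by the values given here, no measured pair covers a change of this sort, so the step from compound 2 to compound 3 gives no direct guide to its size, and the expectation rests on compound 1 alone as the starting point.

For compound 4 the expected result in this assay is 2.3, with a range of 1.7 to 2.9, an estimated step of a number 0.70 log units lower from compound 1 to compound 4 (beyond the scatter) from compound 1, with the direction and size of that step uncertain for want of a comparable measured pair.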

Compound 4, distribution coefficient: 2.2
Beside the measured number, compound 4's estimate is 0.10 log units above it, within the range that was stated.
By their numbers in this assay, from the lowest: compounds 4 and 2 (each within the scatter of the next); then compounds 1 and 3 (each within the scatter of the next).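

In this assay, the aromatic carbon para to a large group proves responsive to substitution: bromo in place of 2-fluoro-3-methylphenyl gives a number 0.80 log units lower from compound 1 to compound 4 (beyond the scatter). For the compounds shown here, until now the only step lay at a nitrogen on an aromatic ring, a number 0.70 log units higher from compound 2 to compound 3 (beyond the scatter), and this pair adds a second place where a single change moves the read-out beyond the scatter, here with the amide side chain and the shared core held constant. No measured evidence on the compounds accounts for this step.

Going by these compounds alone, the single pair at this position exchanges a six-membered aromatic ring carrying fluorine and methyl for a lone bromine, so it cannot separate what the ring itself contributes from what its two substituents or the bromine contribute. An unsubstituted phenyl at the same aromatic carbon would divide the step into those parts, while a methoxy group or an amine there would show whether the read-out also moves with small groups other than bromo.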